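Cyano to 3-hydroxypropyl on the shared core

This account rests on a few compounds, and the source may have more. Where it says the series, first, only, none or still open, it means among the compounds named here.

Values in an ADME assay on microsomes from liver (Canis lupus familiaris) for metabolic stability, with a stated time of 10 min; on this read-out lower numbers stand for a less stable compound and higher numbers for a more stable compound:
- compound 1 `Fc1cc(-c2ccccc2C(F)(F)F)cc2nc(C3=NOC4(CCCCC4)C3)[nH]c12`: 87%
- compound 2 `FC(F)(F)c1ccccc1-c1cc(Cl)c2[nH]c(C3=NOC4(CCCCC4)C3)nc2c1`: 100%
- compound 3 `N#Cc1cc(-c2ccccc2C(F)(F)F)cc2nc(C3=NOC4(CCCCC4)C3)[nH]c12`: 51%

Compound 3 stands lowest of the three, at 51%. Compound 4 `OCCCc1cc(-c2ccccc2C(F)(F)F)cc2nc(C3=NOC4(CCCCC4)C3)[nH]c12` is still unmeasured and differs from it in one place: 3-hydroxypropyl in place of cyano on an aromatic carbon. In words, 3-hydroxypropyl comes in place of cyano on an aromatic carbon.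

All three measured steps concern this same carbon. The step of a number 13 percentage points higher from compound 1 to compound 2 (beyond the scatter) was modest, while a number 36 percentage points lower from compound 1 to compound 3 (beyond the scatter) and a number 49 percentage points lower from compound 2 to compound 3 (beyond the scatter) were large. The read-out has therefore moved widely with the group at this place. Within the data shown here, no measured compound carries a chain there, so these steps give no firm direction for 3-hydroxypropyl.

The expectation stays close to compound 3 at 51%, leaning slightly upward, with a wide range. The expected change is a number 7 percentage points higher from compound 3 to compound 4 (within the scatter), with no step beyond the scatter as the central estimate. The estimate for compound 4 is 58%, with an expected range from 32% to 85%.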

Compound 4, percent of the compound remaining: 12%
Beside the measured number, compound 4's estimate is 46 percentage points above it; measured number outside the range, below it.
By their numbers in this assay, from the lowest: compound 4; then compound 3; then compound 1; then compound 2.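

In this assay the change from cyano to 3-hydroxypropyl on this aromatic carbon is a further fall, with a number 39 percentage points lower from compound 3 to compound 4 (beyond the scatter) in the series. Set against the halogens, the same chain gives a number 75 percentage points lower from compound 1 to compound 4 (beyond the scatter) and a number 88 percentage points lower from compound 2 to compound 4 (beyond the scatter) as the widest steps seen at this place. The nitrile therefore did not mark the bottom for this position, and the order now runs from 3-hydroxypropyl through cyano and fluoro to chloro.

No data bearing on the cause of this fall are available. As far as these compounds go, whether the loss follows the chain itself or its terminal hydroxyl stays open, and a plain propyl chain, a hydroxymethyl group, a longer chain, an amine or a carboxylic acid at this carbon would help to separate the two.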